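Swapping the Anilide Ring in a Cytotoxicity Series

A few compounds are considered here, and "the series" means these few. Any claim that something is new, unique, unknown or untested is made for them only; others in the source may bear on it.

Compound 1 `Cc1ccc(NC(=O)C(=O)NC(c2nc(C)c(CCO)s2)C2CCCCN2)cc1F` in an ADME assay on TZM-b1 cells (Homo sapiens) for cytotoxicity, read by XTT assay, with a stated time of 3 days; a higher number here means that more compound is tolerated, a lower number that less compound is tolerated: compound 1 gives > 85000 nM, a limit of the assay.
Compound 2 `Cc1nc(C(NC(=O)C(=O)Nc2ccc(Cl)cc2)C2CCNCC2)sc1CCO` in this assay: compound 2 gives 85400 nM.
Compound 3 `Cc1nc(C(NC(=O)C(=O)Nc2ccc(F)c(Cl)c2)C2CCCCN2)sc1CO` in this assay: compound 3 gives > 77800 nM, a limit of the assay.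

All three measured compounds share one core and differ only in the ring on the amide-type nitrogen. Compound 3 stands at the limit of > 77800 nM in this assay, at which 1 of the 3 values shown sits, so no true number is known for it, only that the cells tolerated it up to the highest concentration tested. Compound 1 sits at the limit of > 85000 nM in this assay, at which 1 of the 3 values shown sits. Compound 2 gives a measured number that lies close to those limits, so nothing among the three compounds separates one from another.

Compound 4 `CC(=O)c1ccc(NC(=O)C(=O)NC(c2nc(C)c(CO)s2)C2CCCCN2)cc1` carries the change (4-acetylphenyl in place of 3-chloro-4-fluorophenyl on an amide-type nitrogen). For the measured compounds named here, no measured pair shows what such a swap does in this assay, so there is no step to lean on. Since compound 3 stands at the limit of > 77800 nM in this assay, at which 1 of the 3 values shown sits, and the other two compounds sit at or near the same level, the expectation is no change beyond the scatter: the step that the limit leaves unreadable from compound 3 to compound 4 is expected to be flat. Compound 4 is therefore estimated at 80000 nM, within 40000 nM to 120000 nM, most likely again reported as a limit.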

Compound 4, half-maximal cytotoxic concentration: > 86000 nM
Compound 4: no number, only a limit (the forecaster's own chance of this, stated with the estimate: 70%); middle value at least 1.0-fold (0.03 log units) from the limit.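

Compound 3 and compound 4 are each reported only as a limit, and the step between them cannot be read. The compounds shown leave open whether 4-acetylphenyl in place of 3-chloro-4-fluorophenyl changes the true tolerated concentration in this assay at all.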